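Halogen swap on the 2-bromophenyl group of compound 1

The source may hold more compounds than are shown below. What is called first, only, known or untested is meant among the compounds shown, and "the series" means these compounds.

- Compound 1 `CC1(C)[C@H]2CC[C@]1(C)N(Cc1cn(-c3ccccc3Br)nn1)C(=O)C2`: 150 nM
- Compound 2 `CC1(C)[C@H]2CC[C@]1(C)N(Cc1cn(-c3ccc(C#N)cc3)nn1)C(=O)C2`: 50 nM
- Compound 3 `CC1(C)[C@H]2CC[C@]1(C)N(Cc1cn(-c3cccc(C#N)c3)nn1)C(=O)C2`: 40 nM

In a functional assay on HepG2 cells (Homo sapiens) for inhibition, read by MTT assay, with a stated time of 24 h (a lower number here means a stronger inhibitor, a higher number a weaker inhibitor), compound 1 gives 150 nM, the highest number of the three, and its steps to both of the others lie beyond the scatter. The step between the two cyanophenyl compounds stays within the scatter: a 1.3-fold lower number from compound 2 to compound 3 (0.10 log units; within the scatter).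

Compound 4 `CC1(C)[C@H]2CC[C@]1(C)N(Cc1cn(-c3ccccc3Cl)nn1)C(=O)C2` has not yet been measured. It keeps the core of compound 1 and alters one group: chloro in place of bromo on an aromatic carbon. In words, this is chloro in place of bromo on an aromatic carbon, ortho to a large group.

Among the measured compounds shown here, no measured step exchanges one halogen for another. The nearest evidence is a 3.0-fold lower number from compound 1 to compound 2 (0.48 log units; beyond the scatter) and a 3.8-fold lower number from compound 1 to compound 3 (0.57 log units; beyond the scatter). Both are modest, and each replaces the whole 2-bromophenyl group with a cyanophenyl group, so neither isolates the halogen. A change confined to the halogen is therefore expected to give no step beyond the scatter in this assay. The expected step is a 1.2-fold lower number from compound 1 to compound 4 (0.06 log units; within the scatter). For compound 4 the estimated value is 130 nM, with an expected range from 60 nM to 280 nM.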

Compound 4, half-maximal inhibitory concentration: 60 nM
Beside the measured number, compound 4's estimate is 2.2-fold (0.34 log units) above it; low and high end bracket the measured number.
By their numbers in this assay, from the lowest: compounds 3, 2 and 4 (each within the scatter of the next); then compound 1.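

In this assay, among the compounds shown here, the halogen on an aromatic carbon ortho to a large group turns out to matter on its own: a 2.5-fold lower number from compound 1 to compound 4 (0.40 log units; beyond the scatter) comes from exchanging bromo for chloro alone, a change the earlier steps could not isolate, as each replaced the whole 2-bromophenyl group. The 2-chlorophenyl compound also falls level with both cyanophenyl compounds, with a 1.5-fold higher number from compound 3 to compound 4 (0.18 log units; within the scatter) and a 1.2-fold higher number from compound 2 to compound 4 (0.08 log units; within the scatter), so among these four compounds the higher number of compound 1 goes with bromo specifically and not with the presence of a halogen at this place. Nothing available on these compounds explains why the two halogens differ.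

The compounds shown hold only bromo and chloro on this aromatic carbon, so it remains open how fluoro, methyl, methoxy or an amine would read there, and whether the step from bromo to chloro continues in any of these. Going by these compounds, it also remains open how the unsubstituted phenyl group compares, which would show how much of the number of compound 4 depends on having chloro at this place at all.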